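Furan-3-yl for thiophen-2-yl on the saturated ring carbon

The compounds below may be only part of what the source reports. "The series", "measured", "known", "first", "only" and "open" are said of these compounds alone.

Compound 1 `CCOC(=O)C1=C(C(F)(F)F)NC(=O)NC1c1cccs1` is one of two compounds with numbers in an assay on HeLa cells for displacement of a labelled ligand from adenosine receptor A3 (Homo sapiens), read by radioligand binding, with a stated time of 180 min, tested at 1 uM; on this read-out higher numbers stand for more inhibition at the one concentration tested (going by the name of the read-out) and lower numbers for less inhibition. In this assay compound 1 gives 1%, the only number shown for it; a further entry of compound 1 carries no single number. The other measured compound, compound 2 `CC1=C(C(=O)OC(C)C(F)(F)F)C(c2ccco2)NC(=O)N1`, gives 11%; 7% (2 entries) in this assay, and the several entries of compound 2 in this assay, 11%; 7% (2 entries) shows how repeat entries of one compound spread. Compound 2 and compound 1 differ in more than one place, so of that pair only the two values themselves are taken, and they fall within the scatter of each other.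

Compound 3 `CCOC(=O)C1=C(C(F)(F)F)NC(=O)NC1c1ccoc1` has not been measured in this assay. It differs from compound 1 by furan-3-yl in place of thiophen-2-yl on a saturated ring carbon. Going by the values given here, no pair of measured compounds isolates this change, so its size has no precedent. The step is expected to be a number 2 percentage points higher from compound 1 to compound 3 (within the scatter), that is, none beyond the scatter, with compound 1 at 1% as the anchor. Compound 3 is therefore estimated at 3% in this assay, with a range from -8% to 15%.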

Compound 3, a percentage reported as inhibition, at one concentration (the size of the read-out at that concentration, not a potency): 1%
Compound 3: middle estimate off by 2 percentage points, on the high side; measured number inside the range.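

In this assay, going by these compounds alone, furan-3-yl in place of thiophen-2-yl on the saturated ring carbon gives no change at the digits printed from compound 1 to compound 3 (within the scatter), the first step that isolates a change in one place. This step exchanges sulfur for oxygen in the ring and also moves the point of attachment, and at this position the two changes taken together leave the read-out within the scatter; the step alone does not separate them. The step is best read against the spread of repeat entries of a single compound: the several entries of compound 2 in this assay, 11%; 7% (2 entries)

The compounds shown leave open whether a group of a different kind on this saturated ring carbon, such as a longer alkyl chain or a phenyl ring carrying an amine, would move the inhibition at the one concentration tested beyond the scatter. Also open is what a carboxylic acid in place of the ethoxycarbonyl group would do, as no step among the compounds shown touches that group or the trifluoromethyl group.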